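Shortening the sulfonamide and capping its nitrogen in a thiourea series

The source may report more compounds than this note shows. Statements on the series, on what has been measured and on what is new or still open speak of the compounds shown alone.

Three thioureas built on the same core have been measured in a functional assay for antagonist activity at Vanilloid receptor (Rattus norvegicus); a lower number here means a stronger inhibitor, a higher number a weaker inhibitor. Compound 1 `CC(C)(C)c1ccc(C/N=C(\S)NCc2ccc(OS(C)(=O)=O)cc2)cc1` gives 9300 nM, compound 2 `CCCCS(=O)(=O)Nc1ccc(C/N=C(\S)NCc2ccc(C(C)(C)C)cc2)cc1` gives 4100 nM, and compound 3 `CC(C)(C)c1ccc(C/N=C(\S)NCc2ccc(NS(=O)(=O)Cc3ccccc3)cc2)cc1` gives 1500 nM. Compound 2 thus stands second highest of the three numbers, beyond the scatter from both neighbours. Going by the values given here, the one single-point step so far, a 6.2-fold lower number from compound 1 to compound 3 (0.79 log units; beyond the scatter), shows that enlarging the sulfonyl-bearing group to a benzyl sulfonamide pays off. Compound 4 `CN(c1ccc(C/N=C(\S)NCc2ccc(C(C)(C)C)cc2)cc1)S(C)(=O)=O` differs from compound 2 by methyl(methylsulfonyl)amino in place of (butylsulfonyl)amino on an aromatic carbon. This goes the other way: a shorter chain and no hydrogen-bond donor. Compound 1, with the smaller methylsulfonyloxy group and no donor, gives a higher number than compound 2, and compound 3 with the larger sulfonamide gives a lower one. A weaker result is therefore expected for compound 4, with the step from compound 2 to compound 4 estimated at a 2.2-fold higher number from compound 2 to compound 4 (0.34 log units; beyond the scatter). In this assay compound 4 is expected to give about 9000 nM, most likely between 3000 nM and 30000 nM.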

Compound 4, half-maximal inhibitory concentration: 2500 nM
For compound 4 the middle estimate is 3.6-fold (0.56 log units) above the measured one; the measured number lies below the stated range.
By their numbers in this assay, from the lowest: compounds 3, 4 and 2 (each within the scatter of the next, the first and the last beyond it); then compound 1.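

In this assay, replacing (butylsulfonyl)amino with methyl(methylsulfonyl)amino gives a 1.6-fold lower number from compound 2 to compound 4 (0.21 log units; within the scatter), so this position, para to a large group, accepts a shorter chain and the loss of the hydrogen-bond donor without a readable change in the number. Having no such donor here therefore does not by itself give a number as high as that of compound 1, which gives 9300 nM, while compound 4 gives 2500 nM. No measurement at hand explains this result.

Chain and nitrogen change together in this step, so the part played by each stays unresolved, and the methylsulfonylamino group, with the nitrogen hydrogen kept, would separate them. Also open, as far as these compounds go, is how an amine or a carboxylic acid would fare at this position.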